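The compounds below may be only part of what the source reports. "The series", "measured", "known", "first", "only" and "open" are said of these compounds alone.

Measured so far in a functional assay on the whole organism with Mus musculus as the target, in the maximal electroshock model; on this read-out lower numbers stand for an effect already at smaller amounts and higher numbers for an effect only at larger amounts of compound:
- compound 1 `OC1CCN(c2ccc(-c3ccccc3)nn2)CC1`: 86 mg/kg
- compound 2 `OC1CCN(c2ccc(-c3ccc(F)cc3)nn2)CC1`: 48 mg/kg
- compound 3 `Cc1ccc(-c2ccc(N3CCC(O)CC3)nn2)cc1`: 73 mg/kg

Among the measured compounds shown here, compound 2, at 48 mg/kg, has no step to either of the other two that goes beyond the usual scatter, so these three compounds cannot be ranked.

Compound 4 `CNC(=O)OC1CCN(c2ccc(-c3ccc(F)cc3)nn2)CC1` keeps all of compound 2 except at the oxygen of its hydroxy group: methylcarbamoyl in place of hydrogen on an oxygen on a saturated carbon. This is methylcarbamoyl in place of hydrogen on an oxygen on a saturated carbon, which turns hydroxy into (methylcarbamoyl)oxy.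

All three measured steps changed a group on an aromatic carbon. Fluoro for hydrogen gave a 1.8-fold lower number from compound 1 to compound 2 (0.25 log units; within the scatter), methyl for hydrogen gave a 1.2-fold lower number from compound 1 to compound 3 (0.07 log units; within the scatter), and methyl for fluoro gave a 1.5-fold higher number from compound 2 to compound 3 (0.18 log units; within the scatter). None of them touches the oxygen, so they bear on the new change only indirectly, showing that swaps elsewhere in these compounds stayed within the scatter.

For the measured compounds named here, no measured step exists at this place, so no direction can be argued, and the data offer no ground for expecting a step beyond the scatter. The expected size is a 1.1-fold higher number from compound 2 to compound 4 (0.06 log units; within the scatter), an estimate with wide uncertainty. For compound 4 the estimated value is 55 mg/kg, with an expected range from 20 mg/kg to 140 mg/kg in this assay.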

Compound 4, dose for half-maximal effect: 40 mg/kg
Compound 4: the middle estimate sits 1.4-fold (0.14 log units) above what was measured; measured number inside the range.
By their numbers in this assay, from the lowest: compounds 4, 2, 3 and 1 (each within the scatter of the next, the first and the last beyond it).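

Among the compounds shown here, the oxygen of the hydroxy group had not been touched in the earlier compounds, and it now has a first measured step of its own: in this assay, methylcarbamoyl in place of hydrogen gives a 1.2-fold lower number from compound 2 to compound 4 (0.08 log units; within the scatter). This shows that the hydrogen on this oxygen can give way to a much larger group, one that brings its own carbonyl and amide hydrogen, without the number leaving the usual scatter, so the position tolerates at least this one substantial change on this read-out. No measurement available here explains why this change leaves the number within the scatter.

On these data alone, this is a single group on a single compound, so it remains open whether the same change would behave alike on compound 1 or compound 3, which carry hydrogen or methyl where compound 2 carries fluoro. As far as these compounds go, it also remains open whether other replacements at this place, such as an acetyl group on the oxygen or an amine in place of the whole hydroxy group, would stay within the scatter or move the number beyond it.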